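From iodo to ethoxycarbonyl: compound 1 to compound 4

A few compounds are considered here, and "the series" means these few. Any claim that something is new, unique, unknown or untested is made for them only; others in the source may bear on it.

For the measured compounds named here, in an ADME assay on BHK cells (Mesocricetus auratus) for cytotoxicity, read by MTT assay, with a stated time of 96 h (on this read-out lower numbers stand for higher toxicity in this test and higher numbers for lower toxicity in this test), compound 1 `FC(F)(F)c1cccc(NC(=S)Nc2ccc(I)cc2)c1` gives 9400 nM, the only exact number so far. Compound 2 `CCNC(=S)Nc1cccc(C(F)(F)F)c1` gives > 100000 nM, which is a limit. Compound 3 `CSCCCNC(=S)Nc1cccc(C(F)(F)F)c1` gives > 100000 nM, also a limit. Two large measured steps bear only indirectly on what follows: an at least 10-fold higher number from compound 1 to compound 2 (1.02 log units; beyond the scatter) and an at least 10-fold higher number from compound 1 to compound 3 (1.02 log units; beyond the scatter). Each replaced the whole 4-iodophenyl, whereas compound 4 `CCOC(=O)c1ccc(NC(=S)Nc2cccc(C(F)(F)F)c2)cc1` changes only the iodo: ethoxycarbonyl in place of iodo on an aromatic carbon. With those steps from compound 1 not matching this smaller change, no step beyond the scatter is expected in this assay, though any drift would more likely be towards a higher number. The expected step is a 1.5-fold higher number from compound 1 to compound 4 (0.17 log units; within the scatter). For compound 4 the estimate is 14000 nM, within an expected range of 3500 nM to 50000 nM.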

Compound 4, half-maximal cytotoxic concentration: 50000 nM
Beside the measured number, compound 4's estimate is 3.6-fold (0.55 log units) below it; measured number inside the range.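

The earlier steps shown here replaced the whole 4-iodophenyl, so they could not show what the para group alone contributes. In this assay, with the ring kept, ethoxycarbonyl in place of iodo gives a 5.3-fold higher number from compound 1 to compound 4 (0.73 log units; beyond the scatter), so a change on this aromatic carbon alone moves the number beyond the scatter. Compound 4 still gives an exact number, whereas compound 2 and compound 3 give only a limit: the limit of > 100000 nM in this assay, at which 2 of the 4 values shown sit.

Going by these compounds, whether a carboxylic acid, an amine or a longer ester on this aromatic carbon would move the number further remains open.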